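The source may report more compounds than this note shows. Statements on the series, on what has been measured and on what is new or still open speak of the compounds shown alone.

The measured compounds:
compound 1 `O=C1O[C@H]([C@@H](O)Cn2cc(-c3cccc(O)c3)nn2)C(OCc2ccccc2)=C1OCc1ccccc1`: 59900 nM
compound 2 `CCCCCc1ccc(-c2cn(C/C=C3\OC(=O)C(OCc4ccccc4)=C3OCc3ccccc3)nn2)cc1`: > 100000 nM, a limit of the assay
compound 3 `CC(C)(C)OC(=O)N1CCN(C(=S)SCc2cn(C[C@H](O)[C@H]3OC(=O)C(OCc4ccccc4)=C3OCc3ccccc3)nn2)CC1`: > 100000 nM, a limit of the assay

For the measured compounds named here, in a functional assay on A549 cells (Homo sapiens) for antiproliferative activity, read by MTT assay, with a stated time of 72 h (on this read-out higher numbers stand for weaker inhibition and lower numbers for stronger inhibition), compound 1 gives 59900 nM, the only number among the three. Compound 2 reaches only the limit of this assay, > 100000 nM. Compound 3 likewise stops at the limit, > 100000 nM. Compound 1 therefore stands alone as a quantified value, beside (the limit of > 100000 nM in this assay, at which 2 of the 3 values shown sit).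

Compound 4 `O=C1O[C@H]([C@@H](O)Cn2cc(CNS(=O)(=O)c3ccc(F)cc3)nn2)C(OCc2ccccc2)=C1OCc1ccccc1` is not yet measured. It differs from compound 1 by (((4-fluorophenyl)sulfonyl)amino)methyl in place of 3-hydroxyphenyl on an aromatic carbon. Going by the values given here, no measured pair traces this change, so the size of the step is open; weak inhibition is expected to persist, and the step of a 1.3-fold higher number from compound 1 to compound 4 (0.13 log units; within the scatter) is estimated to be small and toward weaker inhibition. Compound 4 is expected at about 80000 nM, within 30000 nM to 200000 nM.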

Compound 4, half-maximal inhibitory concentration: 22500 nM
Compound 4: the middle estimate sits 3.6-fold (0.55 log units) above what was measured; measured number below the stated range.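

On the aromatic carbon of the five-membered aromatic ring with 3 nitrogen, (((4-fluorophenyl)sulfonyl)amino)methyl in place of 3-hydroxyphenyl gives a 2.7-fold lower number from compound 1 to compound 4 (0.43 log units; beyond the scatter) in this assay. For the compounds shown here, this is the first readable step at this position, and it shows that the position tolerates a larger group and responds to the change with stronger inhibition. Compounds 1 and 4 are the only quantified pair here: the limit of > 100000 nM in this assay, at which 2 of the 4 values shown sit.

The whole group changes at once, leaving the contributions of the sulfonyl, the amino link and the fluorine unseparated. From the compounds shown here alone, whether an amine or a carboxylic acid at this position would hold or extend the step remains open.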